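Difluoropropyl Amide Extends the Carboxamide Series

This account rests on a few compounds, and the source may have more. Where it says the series, first, only, none or still open, it means among the compounds named here.

Compound 1, `COCCOC(=O)c1cc(N)c(Nc2ccc(C#N)cc2)cc1Oc1c(C)cc(/C=C/C#N)cc1C`, in a physicochemical assay for lipophilicity, read by HPLC, measured as octanol-water partition, with a stated time of 24 h, at pH 7.4 (on this read-out lower numbers stand for lower lipophilicity and higher numbers for higher lipophilicity), reaches only a limit of the assay, > 5.
Compound 2, `Cc1cc(/C=C/C#N)cc(C)c1Oc1cc(Nc2ccc(C#N)cc2)c(N)cc1C(N)=O`, in this assay gives 3.53.

One measured step connects the two: amino in place of 2-methoxyethoxy on a carbonyl carbon, and it moved this assay by a number at least 1.47 log units lower from compound 1 to compound 2 (beyond the scatter). Among the compounds with values here, compound 2 is therefore the only compound with a number in this assay; the other value is a limit, (the limit of > 5 in this assay, at which 1 of the 2 values shown sits).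

Compound 3, `Cc1cc(/C=C/C#N)cc(C)c1Oc1cc(Nc2ccc(C#N)cc2)c(N)cc1C(=O)NCCC(F)F`, differs from compound 2 by 3,3-difluoropropyl in place of hydrogen on an amide-type nitrogen. Within the data shown here, no measured step has this change. Among the measured compounds shown here, the only step on record, from compound 1 to compound 2, removed a chain from the amide side of the shared core and lowered the read-out strongly; the step to compound 3 adds a chain at the same amide. It is therefore expected to run the other way, and the expected step from compound 2 to compound 3 is a number 1.17 log units higher from compound 2 to compound 3 (beyond the scatter). For compound 3 the estimate in this assay is 4.7, within 4.2 to 5.2.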

Compound 3, partition coefficient: 3.58
The estimate for compound 3 lay 1.12 log units above the measured number, outside the stated range (below it).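

In this assay, the step that puts 3,3-difluoropropyl in place of hydrogen on an amide-type nitrogen comes out as a number 0.05 log units higher from compound 2 to compound 3 (within the scatter), so the plain amide and the substituted amide cannot be told apart on this read-out. The earlier compounds shown here showed only a large step at the carbonyl carbon; now a chain on the amide nitrogen is seen not to bring the number back towards that of compound 1, with (3,3-difluoropropyl)amino in place of 2-methoxyethoxy on a carbonyl carbon giving a number at least 1.42 log units lower from compound 1 to compound 3 (beyond the scatter). On these data alone, the true size of that step stays unknown, since compound 1 stands at a limit of the assay and not at a number: the limit of > 5 in this assay, at which 1 of the 3 values shown sits.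

The compounds shown leave open whether the flat result belongs to this chain alone or to the amide nitrogen in general, which a plain propyl chain without fluorine, a longer chain or a chain ending in an amine at the same nitrogen would help to separate. With a single substituted amide on record, they also offer no trend along the series and no explanation for this result.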